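This account rests on a few compounds, and the source may have more. Where it says the series, first, only, none or still open, it means among the compounds named here.

Measured so far in a functional assay on MKN-45 cells (Homo sapiens) for cytotoxicity, read by MTT assay, with a stated time of 72 h; a higher number here means a weaker inhibitor, a lower number a stronger inhibitor:
- compound 1 `CN(C)CCn1cnnc1-c1cc(Oc2ccc(NC(=O)N/N=C/c3ccc(F)cc3F)cc2F)ccn1`: 810 nM
- compound 2 `CN(C)CCn1cnnc1-c1cc(Oc2ccc(NC(=O)N/N=C/c3ccc(O)c(F)c3)cc2F)ccn1`: 1970 nM

Compound 1 gives the lowest number of the two; compound 2 sits a 2.4-fold higher number from compound 1 to compound 2 (0.39 log units; beyond the scatter). The unmeasured compound 3 `CN(C)CCn1cnnc1-c1cc(Oc2ccc(NC(=O)N/N=C/c3cccc(O)c3)cc2F)ccn1` differs from compound 1 by 3-hydroxyphenyl in place of 2,4-difluorophenyl on a carbon with a double bond to nitrogen. Within the data shown here, the only step that bears on this change is the one from compound 1 to compound 2, where a 3-fluoro-4-hydroxyphenyl replaced the same 2,4-difluorophenyl and gave a modest rise beyond the scatter. A step of similar size and direction is expected here, a 2.2-fold higher number from compound 1 to compound 3 (0.35 log units; beyond the scatter). Compound 3 is therefore estimated at 1800 nM, within a range of 800 nM to 4500 nM.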

Compound 3, half-maximal inhibitory concentration: 1370 nM
Estimate against measurement, compound 3: 1.3-fold (0.12 log units) above; low and high end bracket the measured number.
By their numbers in this assay, from the lowest: compounds 1, 3 and 2 (each within the scatter of the next, the first and the last beyond it).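

In this assay, the change to 3-hydroxyphenyl on this carbon with a double bond to nitrogen gives a 1.7-fold higher number from compound 1 to compound 3 (0.23 log units; within the scatter), and dropping the fluorine of 3-fluoro-4-hydroxyphenyl gives a 1.4-fold lower number from compound 2 to compound 3 (0.16 log units; within the scatter). Compound 3 therefore cannot be separated from either neighbour, although a 2.4-fold higher number from compound 1 to compound 2 (0.39 log units; beyond the scatter), so the three compounds do not resolve into separate levels at this position. No measurement shown accounts for these numbers. Open, going by these compounds, is how a methoxyphenyl or an aminophenyl on the same carbon would compare with the 2,4-difluorophenyl of compound 1.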